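The source may hold more compounds than are shown below. What is called first, only, known or untested is meant among the compounds shown, and "the series" means these compounds.

Series notes. Compound 1 `O=C(NCc1cc(Cl)ccc1-n1cnnn1)[C@@H]1C[C@@H]2C[C@@H]2N1C(=O)[C@H](O)Cc1ccccn1` gives 17 mL.min-1.g-1 in an ADME assay on liver for metabolic stability, with Liver microsome (Homo sapiens) as the target, read by LC-MS, using microsomes; a lower number here means slower removal, a higher number faster removal of the compound. Among the two plain numbers in this assay compound 1 stands lowest; compound 2 `CC(C)(C)C[C@@H](O)C(=O)N1[C@@H]2C[C@@H]2C[C@H]1C(=O)NCc1cc(Cl)ccc1-n1cnnn1` gives 71 mL.min-1.g-1, a higher number that lies beyond the scatter. Compound 3 `CC(C)(C)[C@@H](O)C(=O)N1CC(=O)C[C@H]1C(=O)NCc1cc(Cl)ccc1-n1cnnn1` gives < 12 mL.min-1.g-1 in this assay, which is a limit of the assay and not a number (the limit of < 12 mL.min-1.g-1 in this assay, at which 1 of the 3 values shown sits). Compound 4 `O=C(NCc1cc(Cl)ccc1-n1cnnn1)[C@@H]1C[C@@H]2C[C@@H]2N1C(=O)[C@H](O)c1ccccc1F` is not yet measured and differs from compound 1 by one change: 2-fluorophenyl in place of (pyridin-2-yl)methyl on a saturated chain carbon bound to a carbonyl carbon and an oxygen on a saturated carbon. For the measured compounds named here, no measured pair in the set carries this change, so its size is open. The step from compound 1 to compound 4 is expected to go upward, toward faster removal, by a 2.1-fold higher number from compound 1 to compound 4 (0.31 log units; beyond the scatter) in this assay. Compound 4 is therefore estimated at 35 mL.min-1.g-1, between 15 mL.min-1.g-1 and 80 mL.min-1.g-1.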

Compound 4, intrinsic clearance in microsomes: < 12 mL.min-1.g-1
Compound 4: a limit, no number; the forecaster's own chance of this, stated with the estimate: 10%; middle value at least 2.9-fold (0.46 log units) from the limit.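

In this assay compound 4 gives < 12 mL.min-1.g-1, which is a limit of the assay and not a number. The result shows that this position, on a saturated chain carbon bound to a carbonyl carbon and an oxygen on a saturated carbon, tolerates an aromatic ring of carbon only, with an at least 1.4-fold lower number from compound 1 to compound 4 (0.15 log units; that floor lies within the scatter). Any further difference among such compounds cannot be read at this end of the scale: the limit of < 12 mL.min-1.g-1 in this assay, at which 2 of the 4 values shown sit.

The compounds shown leave open whether the fluorine, the ring nitrogen or the methyl link accounts for the step. As far as these compounds go, how a plain phenyl or a chain carrying an amine would read at this place also stays open.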